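Swapping the Amide Side Chain: Expected Effect on Cytotoxicity

The source may hold more compounds than are shown below. What is called first, only, known or untested is meant among the compounds shown, and "the series" means these compounds.

Measured so far in an ADME assay on HELF cells (Homo sapiens) for cytotoxicity, with a stated time of 3 days; on this read-out higher numbers stand for lower toxicity in this test and lower numbers for higher toxicity in this test:
- compound 1 `CC(C)C[C@H](NC(=O)[C@]1(Cc2ccccc2)CCN1C(=O)OCc1ccccc1)C(N)=O` gives 50000 nM
- compound 2 `C[C@H](NC(=O)[C@]1(Cc2ccccc2)CCN1C(=O)Oc1cccc2ccccc12)C(N)=O` gives > 100000 nM
- compound 3 `C[C@H](NC(=O)[C@]1(Cc2ccccc2)CCN1S(=O)(=O)c1ccc2ccccc2c1)C(N)=O` gives > 100000 nM

All three compounds share the same core and were tested for how strongly they harm the cells in this assay. For the measured compounds named here, compound 1 is the only one with a plain number, 50000 nM. For compound 2 the result is a limit of the assay, not a number. For compound 3 the result is likewise a limit of the assay. Going by the values given here, the rest of the picture is therefore (the limit of > 100000 nM in this assay, at which 2 of the 3 values shown sit), so compound 1 cannot be placed above or below the other two; it simply stands as the only measured number.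

Compound 4 `C[C@H](NC(=O)[C@]1(Cc2ccccc2)CCN1C(=O)OCc1ccccc1)C(=O)NC(C)(C)C` has not been measured yet. It differs from compound 1 in one place: 1-((tert-butyl)carbamoyl)ethyl in place of 1-carbamoyl-3-methylbutyl on an amide-type nitrogen. Among the compounds with values here, no pair of measured compounds shows this kind of change, so there is nothing to size it against. The step expected in this assay is a 1.2-fold higher number from compound 1 to compound 4 (0.08 log units; within the scatter), none beyond the usual scatter. Compound 4 is accordingly expected to give 60000 nM, within a range from 25000 nM to 150000 nM.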

Compound 4, half-maximal cytotoxic concentration: > 100000 nM
Compound 4: only a limit was reported; the forecaster's own chance of this, stated with the estimate: 40%; middle value at least 1.6-fold (0.22 log units) from the limit.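

In this assay the result for compound 4 is a limit of the assay, not a number. Placing 1-((tert-butyl)carbamoyl)ethyl instead of 1-carbamoyl-3-methylbutyl on the amide-type nitrogen gives an at least 2.0-fold higher number from compound 1 to compound 4 (0.30 log units; that floor lies within the scatter), so this position tolerates the change without any sign of greater harm to the cells, although the smallest step this allows is no larger than ordinary repeat variation. Compound 1 remains the only compound with a plain number, and the others share one ceiling: the limit of > 100000 nM in this assay, at which 3 of the 4 values shown sit.

The change to compound 4 alters the side chain and adds the tert-butyl group together, so the compounds shown cannot tell which of the two parts matters. From the compounds shown here alone, what a carboxylic acid in place of the carbamoyl group would do at this position also remains open.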